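The source may hold more compounds than are shown below. What is called first, only, known or untested is meant among the compounds shown, and "the series" means these compounds.

Compound 2 `COc1cc(-c2noc(-c3ccc(N)cc3)n2)cc(OC)c1OC` has the lowest of the three numbers in a functional assay on cells (Splenocyte, Mus musculus, strain BALB/c) for inhibition, read by scintillation counting and thymidine incorporation, with stated times of 48 h and 8 h (on this read-out higher numbers stand for weaker inhibition and lower numbers for stronger inhibition), where compound 2 gives 1700 nM. Compound 1 `COc1cc(-c2noc(-c3ccc(NC(=O)OC(C)(C)C)cc3)n2)cc(OC)c1OC` stands nearest: in this assay compound 1 gives 2200 nM, and the step is a 1.3-fold lower number from compound 1 to compound 2 (0.11 log units; within the scatter). Compound 3 `COc1cc(-c2noc(-c3cccc(N)c3)n2)cc(OC)c1OC` stands furthest: in this assay compound 3 gives 5500 nM, and the step is a 3.2-fold higher number from compound 2 to compound 3 (0.51 log units; beyond the scatter).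

Compound 4 `CCCCc1ccc(-c2nc(-c3cc(OC)c(OC)c(OC)c3)no2)cc1` differs from compound 2 in one place.
butyl in place of amino on an aromatic carbon

Within the data shown here, only one measured step touches the same spot: the change from compound 1 to compound 2 altered what sits on that nitrogen and gave a 1.3-fold lower number from compound 1 to compound 2 (0.11 log units; within the scatter), within the scatter. The step from compound 2 to compound 3 moved the amino group to another position rather than replacing it and gave a 3.2-fold higher number from compound 2 to compound 3 (0.51 log units; beyond the scatter). Neither step replaces the amino group with a butyl chain, so the ground for an expectation is thin. The expected step is a 1.8-fold higher number from compound 2 to compound 4 (0.25 log units; within the scatter), a modest weakening that may not exceed the scatter. Compound 4 is expected to give 3000 nM, with a range from 1000 nM to 12000 nM.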

Compound 4, half-maximal inhibitory concentration: 36200 nM
Beside the measured number, compound 4's estimate is 12-fold (1.08 log units) below it; measured number outside the range, above it.
By their numbers in this assay, from the lowest: compounds 2 and 1 (each within the scatter of the next); then compound 3; then compound 4.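

Among these compounds, replacing the amino group with a butyl chain on this aromatic carbon brings the first large change in this assay: a butyl chain gives a 21-fold higher number from compound 2 to compound 4 (1.33 log units; beyond the scatter) and, set against the carbamate, a 16-fold higher number from compound 1 to compound 4 (1.22 log units; beyond the scatter). The bulky tert-butoxycarbonyl on the nitrogen of compound 1 had left the number within the scatter of compound 2, so this spot tolerates some change, but the butyl result shows that it does not tolerate every group. Nothing measured here explains this loss. A shorter chain such as ethyl would show whether chain length matters, while a hydroxyl or methoxy group would show whether a carbon chain is the problem. A longer chain ending in an amine could test whether restoring a nitrogen to the butyl-length group recovers the lower number.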